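From 3,4-dihydroxyphenyl to 3,4-dimethoxyphenyl at an assay limit

This account rests on a few compounds, and the source may have more. Where it says the series, first, only, none or still open, it means among the compounds named here.

In an ADME assay on HEK-293T cells (Homo sapiens) for cytotoxicity, read by CCK-8 assay, with a stated time of 48 h (a higher number here means a weaker inhibitor, a lower number a stronger inhibitor), compound 1 `O=C(NCCNS(=O)(=O)c1ccc(-c2ccccc2OCc2ccccc2)s1)Nc1cccc([N+](=O)[O-])c1` gives 13300 nM. Compound 2 `O=C(NCCNS(=O)(=O)c1sccc1-c1ccccc1Oc1ccc(O)c(O)c1)Nc1cc(C(F)(F)F)cc(C(F)(F)F)c1` gives 8900 nM. Compound 3 `CC(C)c1ccc(Oc2ccc(O)c(O)c2)c(-c2ccsc2S(=O)(=O)NCCNC(=O)Nc2cc(C(F)(F)F)cc(C(F)(F)F)c2)c1` gives > 20000 nM, which is a limit of the assay and not a number. Compound 3 therefore stands at the limit of > 20000 nM in this assay, at which 1 of the 3 values shown sits.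

Compound 4 `COc1ccc(Oc2ccc(C(C)C)cc2-c2ccsc2S(=O)(=O)NCCNC(=O)Nc2cc(C(F)(F)F)cc(C(F)(F)F)c2)cc1OC` differs from compound 3 in one place: 3,4-dimethoxyphenyl in place of 3,4-dihydroxyphenyl on an oxygen on an aromatic ring. It carries 3,4-dimethoxyphenyl in place of 3,4-dihydroxyphenyl on an oxygen on an aromatic ring.

Among the compounds with values here, only one measured step bears on this change, and only indirectly. It is an at least 2.2-fold higher number from compound 2 to compound 3 (0.35 log units; beyond the scatter), for isopropyl in place of hydrogen on an aromatic carbon. Within the data shown here, that step lies at a different place in the structure, and no measured pair in this assay shows the exchange made in compound 4. It therefore gives no direction for the new change, and no step beyond the scatter is expected. Compound 4 is expected to remain in the region of the limit reached by compound 3, and it may well be reported only as a limit. The estimated step is a step that the limit leaves unreadable from compound 3 to compound 4. For compound 4 the estimated value is 24000 nM, with an expected range from 11000 nM to 50000 nM.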

Compound 4, half-maximal inhibitory concentration: 12100 nM
For compound 4 the middle estimate is 2.0-fold (0.30 log units) above the measured one; the measured number falls inside the stated range.
By their numbers in this assay, from the lowest: compounds 2, 4 and 1 (each within the scatter of the next). At a limit, above all of these: compound 3.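

In this assay, placing 3,4-dimethoxyphenyl where 3,4-dihydroxyphenyl stood on an oxygen on an aromatic ring gives an at least 1.6-fold lower number from compound 3 to compound 4 (0.21 log units; that floor lies within the scatter). Within the data shown here, none of the earlier steps touched this position, and this one shows that, with the isopropyl group kept, the hydrogen-bond donors counted on 3,4-dihydroxyphenyl can be lost while compound 4 still gives a readable number, 12100 nM, rather than a limit of the assay. The true size of the step cannot be read, and even its direction is not secured beyond the scatter, because compound 3 is held at a limit and not a number: the limit of > 20000 nM in this assay, at which 1 of the 4 values shown sits.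

The compounds shown leave open whether the same exchange would give a step that can be read on a parent without the isopropyl group, such as compound 2, whose value stands clear of the limit. They also leave open how a ring with a single methoxy group, or a carboxylic acid or an amine in place of the two methoxy groups, would read at this position in this assay.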